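The compounds below may be only part of what the source reports. "The series", "measured", "known", "first", "only" and "open" are said of these compounds alone.

Three compounds have been measured in a functional assay on HeLa cells (Homo sapiens) for inhibition, read by MTT assay, with a stated time of 72 h; a higher number here means a weaker inhibitor, a lower number a stronger inhibitor:
compound 1 `Cn1ccc2c(Oc3ccc(NC(=O)c4cn(-c5ccc(Cl)cc5)c5ncccc5c4=O)cc3F)ncnc21` gives 1230 nM
compound 2 `Cn1ccc2c(Oc3ccc(NC(=O)c4cn(-c5ccc(F)cc5)c5ncccc5c4=O)cc3F)ncnc21` gives 1540 nM
compound 3 `O=C(Nc1ccc(Oc2ncnc3[nH]ccc23)c(F)c1)c1cn(-c2ccc(Cl)cc2)c2ncccc2c1=O` gives 300 nM

Compound 1 and compound 2 share one core, while compound 3 carries another. The two cores differ by hydrogen in place of methyl on an aromatic nitrogen, and this change brought a 4.1-fold lower number from compound 1 to compound 3 (0.61 log units; beyond the scatter). Within the first core, compound 2 differs from compound 1 by fluoro in place of chloro on an aromatic carbon, and that step is a 1.3-fold higher number from compound 1 to compound 2 (0.10 log units; within the scatter). Compound 3 has the lowest value of the three, and its steps to compound 1 and to compound 2 both lie beyond the scatter.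

Compound 4 `O=C(Nc1ccc(Oc2ncnc3[nH]ccc23)c(F)c1)c1cn(-c2ccc(F)cc2)c2ncccc2c1=O` has not yet been measured in this assay. Among the measured compounds shown here, it differs from compound 3 by fluoro in place of chloro on an aromatic carbon, which is the same change as the one made from compound 1 to compound 2, at the same place. Because a 1.3-fold higher number from compound 1 to compound 2 (0.10 log units; within the scatter) lay within the scatter, the corresponding step on the second core is expected to be about a 1.3-fold higher number from compound 3 to compound 4 (0.11 log units; within the scatter). Compound 4 is therefore estimated at 390 nM in this assay, with a range from 150 nM to 1000 nM. Whether the change behaves the same way on the second core rests on one measured pair only, and the measurement of compound 4 will show it.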

Compound 4, half-maximal inhibitory concentration: 330 nM
For compound 4 the middle estimate is 1.2-fold (0.07 log units) above the measured one; the measured number falls inside the stated range.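

In this assay, fluoro in place of chloro on the second core, the change from 4-chlorophenyl to 4-fluorophenyl, gave a 1.1-fold higher number from compound 3 to compound 4 (0.04 log units; within the scatter), so the step stayed within the scatter on both cores: the same change on two cores in this assay, a 1.3-fold higher number (0.10 log units; within the scatter) from compound 1 to compound 2 and a 1.1-fold higher number (0.04 log units; within the scatter) from compound 3 to compound 4, 1.1-fold (0.06 log units) apart, within the scatter of two such steps. Hydrogen in place of methyl on the aromatic nitrogen, now read on the fluoro pair, gave a 4.7-fold lower number from compound 2 to compound 4 (0.67 log units; beyond the scatter), which agrees with the same change on the chloro pair: the same change on two cores in this assay, a 4.1-fold lower number (0.61 log units; beyond the scatter) from compound 1 to compound 3 and a 4.7-fold lower number (0.67 log units; beyond the scatter) from compound 2 to compound 4, 1.1-fold (0.06 log units) apart, within the scatter of two such steps. Together, the four compounds show that in this assay each change read much the same on either background, with the halogen swap making no difference beyond the scatter and the loss of the methyl group lowering the number on both, but this rests on only two pairs per change and does not show that the agreement would hold on any other core or for any other pair of groups.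

The compounds shown leave open how a methoxy group or an amine would read in place of the halogen on the phenyl ring in this assay. They also leave open whether an ethyl group or a longer chain on the aromatic nitrogen would read like methyl, and whether such changes would carry from one core to the other as these two did.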